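This account rests on a few compounds, and the source may have more. Where it says the series, first, only, none or still open, it means among the compounds named here.

In a functional assay on NCI-H1975 cells (Homo sapiens) for antiproliferative activity, read by MTT assay, with a stated time of 72 h (on this read-out lower numbers stand for stronger inhibition and higher numbers for weaker inhibition), compound 3, whose structure is `COc1cc2ncnc(Nc3ccc(Cl)cc3)c2cc1OCCCCC(=O)Nc1ccc(S(N)(=O)=O)cc1`, gives 31800 nM, the higher of the two numbers obtained so far, and compound 1, `C#Cc1cccc(Nc2ncnc3cc(OC)c(OCCCCC(=O)Nc4ccc(S(N)(=O)=O)cc4)cc23)c1`, gives 18800 nM, a neighbouring result reached by a 1.7-fold higher number from compound 1 to compound 3 (0.23 log units; within the scatter). Compound 2, `COc1cc2ncnc(Nc3cccc(F)c3)c2cc1OCCCCC(=O)Nc1ccc(S(N)(=O)=O)cc1`, yields in this assay only a limit, > 40000 nM, rather than a number. The limit is described by the limit of > 40000 nM in this assay, at which 1 of the 3 values shown sits.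

The step under consideration leads to compound 4, `COc1cc2ncnc(Nc3ccc(F)c(Br)c3)c2cc1OCCCCC(=O)Nc1ccc(S(N)(=O)=O)cc1`, and consists of 3-bromo-4-fluorophenyl in place of 4-chlorophenyl on a nitrogen on an aromatic ring. Among the compounds with values here, the measured steps that touch the same position are small: a 1.7-fold higher number from compound 1 to compound 3 (0.23 log units; within the scatter) and an at least 1.2-fold lower number from compound 2 to compound 3 (0.09 log units; that floor lies within the scatter), while an at least 2.1-fold higher number from compound 1 to compound 2 (0.32 log units; beyond the scatter) is the only change at this aryl group that moved beyond the scatter. Exchanging one substituted phenyl for another on this nitrogen has therefore altered the result only modestly among compounds 1, 2 and 3, so no move beyond the scatter is expected here either.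

The estimate for compound 4 in this assay is 30000 nM, with a range from 12000 nM to 60000 nM, which is expected to mean a 1.1-fold lower number from compound 3 to compound 4 (0.03 log units; within the scatter).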

Compound 4, half-maximal inhibitory concentration: 31600 nM
The estimate for compound 4 lay 1.1-fold (0.02 log units) below the measured number; measured number inside the range.
By their numbers in this assay, from the lowest: compounds 1, 4 and 3 (each within the scatter of the next). At a limit, above all of these: compound 2.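

In this assay, a phenyl ring carrying two halogens serves no differently from one carrying a single chlorine, a point that compounds 1, 2 and 3, each with one substituent on this ring, could not show: a 1.0-fold lower number from compound 3 to compound 4 (0.00 log units; within the scatter). The second substituent therefore adds nothing that this read-out can separate, and the ethynyl compound also stays within the scatter of the new one, with a 1.7-fold higher number from compound 1 to compound 4 (0.23 log units; within the scatter). Compound 2 remains a limit rather than a number, so an at least 1.2-fold lower number from compound 2 to compound 4 (0.10 log units; that floor lies within the scatter) gives only a floor, and the one value of this kind is recorded as follows: the limit of > 40000 nM in this assay, at which 1 of the 4 values shown sits.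

All the aryl groups shown carry only halogens or ethynyl, so it remains open whether an amine or a carboxylic acid on this phenyl ring would move the number beyond the scatter. The chain and the far end of the molecule are also the same throughout, which leaves open whether a longer chain, or an amine in place of the far-end group, would matter more than any change at this nitrogen.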